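The source may hold more compounds than are shown below. What is called first, only, known or untested is meant among the compounds shown, and "the series" means these compounds.

Working notes on the pyrimidine-fused series. Among the compounds with values here, compound 1 `Cn1c(=O)c(S(=O)(=O)c2ccc(F)cc2F)cc2cnc(Nc3ccc4[nH]c(C(=O)O)cc4c3)nc21` is one of two compounds measured in a functional assay on K562 cells (Homo sapiens) for inhibition, read by trypan blue exclusion, with a stated time of 72 h; a higher number here means a weaker inhibitor, a lower number a stronger inhibitor; in this assay compound 1 gives 10000 nM, the lowest of the two numbers. Within the data shown here, compound 2 `COc1ccc(Nc2ncc3cc(S(=O)(=O)c4ccc(C)cc4)c(=O)n(C)c3n2)cc1` in this assay gives 75000 nM, a higher number than compound 1, and the gap lies beyond the usual scatter; compound 2 differs from compound 1 in more than one place, so the two values show only that compound 1 is the stronger inhibitor of the pair.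

Compound 3 `Cn1c(=O)c(S(=O)(=O)c2ccc(F)cc2F)cc2cnc(Nc3ccc4c(c3)C(=O)C(=O)N4)nc21` has not yet been measured. It differs from compound 1 as follows: a group of 11 heavy atoms (8 carbon, 1 nitrogen, 2 oxygen; one five-membered non-aromatic ring with 1 hetero atom, one six-membered aromatic ring of carbon only) in place of a group of 12 heavy atoms (9 carbon, 1 nitrogen, 2 oxygen; one five-membered aromatic ring with 1 hetero atom, one six-membered aromatic ring of carbon only), on a nitrogen on an aromatic ring. Among the measured compounds shown here, no step between measured compounds isolates this change, so the direction is open. The carboxylic acid of compound 1 is gone and a dione enters in a non-aromatic five-membered ring; a step of modest size in either direction, possibly none beyond the scatter, is expected. For compound 3 the expected value in this assay is 15000 nM, within 3000 nM to 60000 nM. The estimated step of a 1.5-fold higher number from compound 1 to compound 3 (0.18 log units; within the scatter) reflects this uncertainty.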

Compound 3, half-maximal inhibitory concentration: 30000 nM
The estimate for compound 3 lay 2.0-fold (0.30 log units) below the measured number, within the range that was stated.
By their numbers in this assay, from the lowest: compound 1; then compound 3; then compound 2.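

In this assay, placing the group with the five-membered non-aromatic ring on a nitrogen on an aromatic ring, in place of 2-carboxy-1H-indol-5-yl, gives a 3.0-fold higher number from compound 1 to compound 3 (0.48 log units; beyond the scatter). Within the data shown here, this is the first comparison with the rest of compound 1 held fixed, and it shows that the number responds to a change at this position. The change removes the carboxylic acid and the five-membered aromatic ring together, and nothing measured here explains the step or assigns it to either feature.

Whether the carboxylic acid alone accounts for the step remains open, and a methyl ester or primary amide in its place on the 2-carboxy-1H-indol-5-yl group would separate the two features. Also open, on these data alone, is whether any group at this position can give a lower number than compound 1 does.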